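A few compounds are considered here, and "the series" means these few. Any claim that something is new, unique, unknown or untested is made for them only; others in the source may bear on it.

Compound 1, `CN(C)C(=O)c1cccnc1NCCCN1CCN(c2ccccc2)CC1`, gives 15.9 nM in a functional assay on aorta for antagonist activity at Alpha-1D adrenergic receptor (Rattus norvegicus); on this read-out higher numbers stand for weaker binding and lower numbers for tighter binding.
Compound 2, `CN(C)C(=O)c1cccnc1NCCCN1CCN(c2ccccc2O)CC1`, gives 63.1 nM.
Compound 3, `CN(C)C(=O)c1cccnc1NCCCN1CCN(c2ccccc2OC(F)(F)F)CC1`, gives 100 nM.

Among these three, compound 3 holds the highest number in this assay: a 1.6-fold higher number from compound 2 to compound 3 (0.20 log units; within the scatter), which is within the scatter, whereas a 6.3-fold higher number from compound 1 to compound 3 (0.80 log units; beyond the scatter) lies beyond it. Compound 4, `CN(C)C(=O)c1cccnc1NCCCN1CCN(c2ccccc2OCC2CC2)CC1`, differs from compound 3 by cyclopropylmethyl in place of trifluoromethyl on an oxygen on an aromatic ring. For the measured compounds named here, the only measured step touching this oxygen is a 1.6-fold higher number from compound 2 to compound 3 (0.20 log units; within the scatter), and it was small; no measured pair compares two different groups on that oxygen, so the effect of the exchange is uncertain. Compound 4 is therefore expected to show a change of no change at the digits printed from compound 3 to compound 4 (within the scatter), not beyond the scatter. In this assay compound 4 is estimated at 100 nM, in the range 40 nM to 250 nM.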

Compound 4, dissociation constant: 10 nM
The estimate for compound 4 lay 10-fold (1.00 log units) above the measured number; the measured number lies below the stated range.
By their numbers in this assay, from the lowest: compounds 4 and 1 (each within the scatter of the next); then compounds 2 and 3 (each within the scatter of the next).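

On this oxygen the group itself counts in this assay: two groups of equal heavy-atom count part clearly (a 10-fold lower number from compound 3 to compound 4 (1.00 log units; beyond the scatter)), and cyclopropylmethyl also parts from the free hydroxy (a 6.3-fold lower number from compound 2 to compound 4 (0.80 log units; beyond the scatter)). Cyclopropylmethoxy in place of hydrogen on the aromatic carbon, by contrast, stays within the scatter (a 1.6-fold lower number from compound 1 to compound 4 (0.20 log units; within the scatter)), unlike hydroxy and trifluoromethoxy. No measurement shown accounts for this difference between the groups.

On these data alone, it remains open whether methoxy or cyclohexylmethyl on this oxygen would fall with cyclopropylmethyl or with trifluoromethyl. Whether an amine at the same aromatic carbon would hold up is also unsettled.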